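Benzyl for Cyclohexyl on a Sulfonylurea Nitrogen

The source may report more compounds than this note shows. Statements on the series, on what has been measured and on what is new or still open speak of the compounds shown alone.

Compound 1 `CCCCNC(=O)NS(=O)(=O)c1ccc(-n2nc(-c3ccc(Cl)cc3)ccc2=O)cc1`: 100%
Compound 2 `O=C(NC1CCCCC1)NS(=O)(=O)c1ccc(-n2nc(-c3ccc(Cl)cc3)ccc2=O)cc1`: 114%

In a functional assay on the whole organism (blood, strain Wistar albino) for inhibition, with Rattus norvegicus as the target, read by colorimetric assay, with stated times of 15 min and 90 min, at a dose of 20 mg/kg by the oral route (on this read-out lower numbers stand for less inhibition and higher numbers for more inhibition at the one dose given (going by the name of the read-out)), compound 1 gives 100% and compound 2 gives 114%. Compound 2 stands highest of the two, and the step of a number 14 percentage points higher from compound 1 to compound 2 (beyond the scatter) lies beyond the scatter. Compound 3 `O=C(NCc1ccccc1)NS(=O)(=O)c1ccc(-n2nc(-c3ccc(Cl)cc3)ccc2=O)cc1` differs from compound 2 by benzyl in place of cyclohexyl on an amide-type nitrogen. No measured step swaps a ring for a ring on this nitrogen; the one step shown, from butyl to cyclohexyl, was modest, so only a small change, if any, is expected here. Compound 3 is therefore estimated at 105%, between 85% and 125%, an expected step of a number 9 percentage points lower from compound 2 to compound 3 (within the scatter).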

Compound 3, a percentage reported as inhibition, in the whole organism at one dose (the size of the read-out at that dose, not a potency): 111%
The estimate for compound 3 lay 6 percentage points below the measured number, and the stated range covers the measured number.
By their numbers in this assay, from the lowest: compound 1; then compounds 3 and 2 (each within the scatter of the next).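

In this assay, benzyl on this amide-type nitrogen cannot be told apart from cyclohexyl (a number 3 percentage points lower from compound 2 to compound 3 (within the scatter)), so an aromatic ring serves here as well as a non-aromatic one. Benzyl also keeps a modest edge over butyl (a number 11 percentage points higher from compound 1 to compound 3 (beyond the scatter)), so among these three compounds that edge is not unique to cyclohexyl. Nothing available explains these numbers. On these data alone, it remains open how a plain phenyl group directly on this nitrogen would compare, or a longer chain such as hexyl. A benzyl ring carrying an amine or a carboxylic acid is equally unsettled.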